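A Methyl Added to an Inactive Pair

The source may report more compounds than this note shows. Statements on the series, on what has been measured and on what is new or still open speak of the compounds shown alone.

Compound 1, `COCn1c(CC(O)(COCc2ccccc2)COCc2ccccc2)cc(=O)[nH]c1=O`, in a functional assay on HeLa cells (Homo sapiens) for antiproliferative activity, read by MTT assay, with a stated time of 72 h; a lower number here means a stronger inhibitor, a higher number a weaker inhibitor: > 100000 nM, a limit of the assay and not a number.
Compound 2, `COCn1c(CC(COCc2ccccc2)COCc2ccccc2)cc(=O)[nH]c1=O`, in this assay: > 100000 nM, likewise a limit of the assay.

Both measured compounds sit at the same limit, so the step that the two limits leave unreadable from compound 1 to compound 2 cannot be given a size. On the numbers shown, compound 2 stands at the limit together with compound 1, as recorded in the limit of > 100000 nM in this assay, at which 2 of the 2 values shown sit. Compound 3, `COCn1c(CC(COCc2ccccc2)COCc2ccccc2)c(C)c(=O)[nH]c1=O`, differs from compound 2 by methyl in place of hydrogen on an aromatic carbon. For the measured compounds named here, the only measured step, from compound 1 to compound 2, is unreadable, so no measured step gives a size for this new change, and nothing in the data points to a move beyond the scatter in either direction. Compound 3 is therefore expected to remain at the limit, estimated near 150000 nM with a range from 30000 nM to 600000 nM. The expected step is a step that the limit leaves unreadable from compound 2 to compound 3.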

Compound 3, half-maximal inhibitory concentration: 29700 nM
Estimate against measurement, compound 3: 5.1-fold (0.70 log units) above, and the stated range ends above it.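

Putting methyl in place of hydrogen on this aromatic carbon gives, in this assay, an at least 3.3-fold lower number from compound 2 to compound 3 (0.52 log units; beyond the scatter). For the compounds shown here, this position, ortho to a large group, therefore responds to a change of a single carbon, and compound 3 is the only one of the three compounds with a number instead of a limit. The earlier pair could show no size of this kind, because the step between its two members cannot be read: the limit of > 100000 nM in this assay, at which 2 of the 3 values shown sit.

As far as these compounds go, it remains open whether a longer chain such as ethyl, a chlorine atom or an amine on the same carbon would give a similar change. From the compounds shown here alone, the true size of the step also stays unknown with compound 2 held at a limit of the assay, and these compounds do not tell what a hydroxy group on the saturated chain would do with the methyl present.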